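The compounds below may be only part of what the source reports. "The series", "measured", "known", "first", "only" and "open" are said of these compounds alone.

In a functional assay on HCC78 cells (Homo sapiens) for antiproliferative activity, read by MTT assay, with a stated time of 48 h (a lower number here means a stronger inhibitor, a higher number a weaker inhibitor), three related compounds have been measured, and all three numbers are large. Compound 1 (`COc1cccc(CNC(=O)c2cccc(C(C)Oc3cccnc3Nc3cnn(C)c3)c2)c1`) gives 78600 nM, compound 2 (`Cc1ccc(CNC(=O)c2cccc(C(C)Oc3cccnc3Nc3nccs3)c2)cc1`) gives 27100 nM, and compound 3 (`Cc1ccc(CNC(=O)c2cccc(C(C)Oc3ccnc(Nc4cn(C)nc4C)c3)c2)cc1`) gives 17500 nM. Compound 3 and compound 2 lie within the usual scatter of each other, while compound 1 stands clearly apart with a higher number. Compound 4 (`Cc1ccc(CNC(=O)c2cccc(C(C)Oc3ccnc(NN4CCCCC4)c3)c2)cc1`) has piperidin-1-yl in place of the 1,3-dimethyl-1H-pyrazol-4-yl of compound 3, on a nitrogen on an aromatic ring: piperidin-1-yl in place of 1,3-dimethyl-1H-pyrazol-4-yl on a nitrogen on an aromatic ring. Among the measured compounds shown here, no measured pair shows this swap, so only a small weakening in this assay is expected, within the scatter. The estimated change is a 1.6-fold higher number from compound 3 to compound 4 (0.20 log units; within the scatter). For compound 4 the estimated value is 28000 nM, with a range from 11000 nM to 75000 nM.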

Compound 4, half-maximal inhibitory concentration: 24500 nM
Compound 4: middle estimate off by 1.1-fold (0.06 log units), on the high side; low and high end bracket the measured number.
By their numbers in this assay, from the lowest: compounds 3, 4 and 2 (each within the scatter of the next); then compound 1.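

In this assay, piperidin-1-yl in place of 1,3-dimethyl-1H-pyrazol-4-yl on a nitrogen on an aromatic ring gives a 1.4-fold higher number from compound 3 to compound 4 (0.15 log units; within the scatter). Among the compounds shown here, this is the first pair differing in one place, and it shows that a six-membered non-aromatic ring can stand where a five-membered aromatic ring stood without a change beyond the scatter. No measurement at hand bears on why the two compounds match. Still open, from the compounds shown here alone, is whether a different group here, such as morpholin-4-yl or a plain amine, would give a number clearly apart from these.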